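A few compounds are considered here, and "the series" means these few. Any claim that something is new, unique, unknown or untested is made for them only; others in the source may bear on it.

Compound 1 `CCOC(=O)CCCCN(Cc1ccccc1)Cc1ccc2ccccc2c1`: 0%
Compound 2 `O=C(CN(Cc1ccccc1)Cc1ccc2ccccc2c1)OCCO`: 0%

In an assay on HEK293 cells for binding affinity to Substance-K receptor (Rattus norvegicus), read by FRET, tested at 10 uM (a higher number here means more inhibition at the concentration tested (going by the name of the read-out), a lower number less inhibition), compound 1 gives 0%, and compound 2 gives 0%. The single measured step, no change at the digits printed from compound 1 to compound 2 (within the scatter), leaves compound 2 level with compound 1 at the digits shown, so neither of these two compounds shows inhibition at the concentration tested.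

Compound 3 `c1ccc(CN(Cc2ccc3ccccc3c2)c2ccncn2)cc1` differs from compound 2 in one place: pyrimidin-4-yl in place of ((2-hydroxyethoxy)carbonyl)methyl on an amine nitrogen. For the measured compounds named here, the only measured step bears on this change just loosely: it exchanged one ester-bearing chain for another on a saturated chain carbon, and it showed no change. Nothing measured here tells how an aromatic ring entering on the amine nitrogen behaves in this assay . With both measured compounds at the bottom of the scale, the step from compound 2 to compound 3 is expected to be small, a number 5 percentage points higher from compound 2 to compound 3 (within the scatter), though the lack of a guiding example leaves room upward. Compound 3 is therefore estimated at 5% in this assay , within -10% to 30%.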

Compound 3, a percentage reported as inhibition, at one concentration (the size of the read-out at that concentration, not a potency): 34%
Estimate against measurement, compound 3: 29 percentage points below, and the stated range ends below it.
By their numbers in this assay, from the lowest: compounds 1 and 2 (each within the scatter of the next); then compound 3.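

In this assay, the amine nitrogen turns out to be a place where a change can register: pyrimidin-4-yl in place of ((2-hydroxyethoxy)carbonyl)methyl gives a number 34 percentage points higher from compound 2 to compound 3 (beyond the scatter), and pyrimidin-4-yl in place of 4-(ethoxycarbonyl)butyl gives a number 34 percentage points higher from compound 1 to compound 3 (beyond the scatter). The exchange of one ester-bearing chain for another had given no change at the digits printed from compound 1 to compound 2 (within the scatter), so the rise appears only when the chain leaves and a six-membered aromatic ring with 2 hetero atoms enters on the nitrogen. Nothing available explains this rise.

The compounds shown leave open whether the rise belongs to pyrimidin-4-yl itself or would also come with a phenyl or pyridinyl ring, or with a short chain ending in an amine, on this nitrogen. It also remains open what potency lies behind this reading at a single concentration.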